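Bromo to methyl on the 4-bromophenyl group

The source may report more compounds than this note shows. Statements on the series, on what has been measured and on what is new or still open speak of the compounds shown alone.

In a functional assay on SGC-7901 cells (Homo sapiens) for inhibition, read by MTT assay, with a stated time of 24 h (on this read-out lower numbers stand for stronger inhibition and higher numbers for weaker inhibition), compound 1 `CC1(C)[C@H]2CC[C@]1(C)N(Cc1cn(-c3ccccc3C#N)nn1)C(=O)C2` gives 260 nM and compound 2 `CC1(C)[C@H]2CC[C@]1(C)N(Cc1cn(-c3ccc(Br)cc3)nn1)C(=O)C2` gives 450 nM. Within the data shown here, the only measured step is a 1.7-fold higher number from compound 1 to compound 2 (0.24 log units; within the scatter), so compound 2 cannot be separated from compound 1 on these numbers.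

Compound 3 `Cc1ccc(-n2cc(CN3C(=O)C[C@@H]4CC[C@@]3(C)C4(C)C)nn2)cc1` differs from compound 2 at one place: methyl in place of bromo on an aromatic carbon, para to a large group. Among the measured compounds shown here, the measured step bears on this only indirectly, as it swaps 2-cyanophenyl for 4-bromophenyl, and no measured pair isolates bromo against methyl. For the measured compounds named here, with only that small step as a guide, no change beyond the scatter is expected in this assay, in either direction. The expected step is a 1.1-fold lower number from compound 2 to compound 3 (0.05 log units; within the scatter). For compound 3 the estimated value is 400 nM, with an expected range of 180 nM to 900 nM.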

Compound 3, half-maximal inhibitory concentration: 390 nM
Compound 3: the middle estimate sits 1.0-fold (0.01 log units) above what was measured, within the range that was stated.
By their numbers in this assay, from the lowest: compounds 1, 3 and 2 (each within the scatter of the next).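

Among these compounds, the change from 4-bromophenyl to 4-methylphenyl is the first pair to isolate this position in this assay and gives a 1.2-fold lower number from compound 2 to compound 3 (0.06 log units; within the scatter), so bromo and methyl cannot be told apart at this site on these numbers. The comparison with the nitrile-bearing compound gives a 1.5-fold higher number from compound 1 to compound 3 (0.18 log units; within the scatter), which leaves the 2-cyanophenyl, 4-bromophenyl and 4-methylphenyl groups inseparable on this read-out. No measurement at hand speaks to why these groups read alike.

Still open, on these data alone, is whether a group of another kind at the place para to a large group, such as an amine, a carboxylic acid or a longer alkyl chain, would move the number beyond the scatter. The compounds shown also leave open whether any group on this ring can do so.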